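The compounds below may be only part of what the source reports. "The series", "measured", "known", "first", "only" and "open" are said of these compounds alone.

Working notes on the series in a functional assay on CCRF-CEM cells (Homo sapiens) for antiproliferative activity, read by MTT assay, with a stated time of 48 h, tested at 25 uM; a higher number here means a weaker effect of the compound at the concentration tested, a lower number a stronger effect.

Compound 1 `OC(CCn1nc2c(Br)c(Br)c(Br)c(Br)c2n1)c1ccc(Br)cc1` gives 69% and holds the highest number of the three measured compounds, so its effect at the tested concentration is the weakest. Compound 2 `OC(CCn1nc2c(Br)c(Br)c(Br)c(Br)c2n1)c1cccc(Br)c1` gives 54%, and compound 3 `COc1cccc(C(O)CCn2nc3c(Br)c(Br)c(Br)c(Br)c3n2)c1` gives 50%. Both steps away from compound 1 lie beyond the scatter: a number 15 percentage points lower from compound 1 to compound 2 (beyond the scatter) and a number 19 percentage points lower from compound 1 to compound 3 (beyond the scatter). Among the measured compounds shown here, the one step that keeps the phenyl substituent in place and swaps only the group, a number 4 percentage points lower from compound 2 to compound 3 (within the scatter), stays within the scatter.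

Compound 4 `OC(CCn1nc2c(Br)c(Br)c(Br)c(Br)c2n1)c1ccc(F)cc1` differs from compound 1 by fluoro in place of bromo on an aromatic carbon. Only the swap step bears directly on it, and it was small, so no step beyond the scatter is expected; the step from compound 1 to compound 4 is expected to be a number 4 percentage points lower from compound 1 to compound 4 (within the scatter). Compound 4 is estimated at 65%, with a range of 50% to 80%.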

Compound 4, a percentage reported as activity, at one concentration (the size of the read-out at that concentration, not a potency): 88%
Compound 4: middle estimate off by 23 percentage points, on the low side; the measured number lies above the stated range.
By their numbers in this assay, from the lowest: compounds 3 and 2 (each within the scatter of the next); then compound 1; then compound 4.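

Fluoro in place of bromo on this aromatic carbon, para to a large group, is not a neutral swap, a number 19 percentage points higher from compound 1 to compound 4 (beyond the scatter), unlike methoxy in place of bromo between the two 3-substituted phenyl compounds, a number 4 percentage points lower from compound 2 to compound 3 (within the scatter). The gap to those compounds is wide, a number 38 percentage points higher from compound 3 to compound 4 (beyond the scatter) and a number 34 percentage points higher from compound 2 to compound 4 (beyond the scatter), which leaves compound 4 with the weakest effect of the four at the tested concentration. Nothing measured here accounts for the difference between fluoro and bromo at this position.

Still open, on these data alone, is how 4-chlorophenyl or 4-methoxyphenyl would read at this position. Also open, as far as these compounds go, is whether 3-fluorophenyl would fall with compound 2 and compound 3 or with compound 4.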